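The source may report more compounds than this note shows. Statements on the series, on what has been measured and on what is new or still open speak of the compounds shown alone.

Compound 1 `CCCCCCCCc1ccc(OCC(=O)Cn2nnnc2-c2ccccc2)cc1` gives 71 nM in an assay on microsomes from brain for inhibition of Fatty-acid amide hydrolase 1 (Rattus norvegicus), read by fluorescence and HPLC, with a stated time of 60 min; a higher number here means a weaker inhibitor, a lower number a stronger inhibitor. Compound 2 `CCCCCCCCc1ccc(OCC(=O)Cn2nnnc2-c2ccc(S(=O)(=O)N(C)C)cc2)cc1` gives 1400 nM, and compound 3 `CCCCCCCCc1ccc(OCC(=O)Cn2nnnc2-c2cccc(S(=O)(=O)N(C)C)c2)cc1` gives 1900 nM; these two sit together at the weak end, a 1.4-fold higher number from compound 2 to compound 3 (0.13 log units; within the scatter), while the steps of a 27-fold higher number from compound 1 to compound 3 (1.43 log units; beyond the scatter) and a 20-fold higher number from compound 1 to compound 2 (1.29 log units; beyond the scatter) both show a large loss when dimethylsulfamoyl is added to the shared core. Compound 4 `CCCCCCCCc1ccc(OCC(=O)Cn2nnnc2-c2cccs2)cc1` differs from compound 3 by thiophen-2-yl in place of 3-(dimethylsulfamoyl)phenyl on an aromatic carbon. Among the compounds with values here, since this removes the dimethylsulfamoyl that accompanied both large steps, a large fall in this assay is expected, back toward the number of compound 1; no measured pair shows whether thiophen-2-yl matches phenyl. Compound 4 is therefore expected at 90 nM, within 30 nM to 400 nM, a step of a 21-fold lower number from compound 3 to compound 4 (1.32 log units; beyond the scatter).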

Compound 4, half-maximal inhibitory concentration: 55 nM
Estimate against measurement, compound 4: 1.6-fold (0.21 log units) above, and the stated range covers the measured number.
By their numbers in this assay, from the lowest: compounds 4 and 1 (each within the scatter of the next); then compounds 2 and 3 (each within the scatter of the next).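

In this assay, thiophen-2-yl on this aromatic carbon recovers the whole loss seen with the sulfamoyl-bearing rings, in two large steps (a 35-fold lower number from compound 3 to compound 4 (1.54 log units; beyond the scatter)) and (a 25-fold lower number from compound 2 to compound 4 (1.41 log units; beyond the scatter)). The step from phenyl (a 1.3-fold lower number from compound 1 to compound 4 (0.11 log units; within the scatter)) lies within the scatter, so this position takes a five-membered aromatic ring with 1 hetero atom and a six-membered aromatic ring of carbon only about equally. No measurement here accounts for these steps. On these data alone, it remains open whether other five-membered rings, such as furan-2-yl, behave alike. Also open, as far as these compounds go, is whether a phenyl carrying an amine or a carboxylic acid suffers the same loss as dimethylsulfamoyl.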